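This account rests on a few compounds, and the source may have more. Where it says the series, first, only, none or still open, it means among the compounds named here.

In a functional assay on MEL28 cells (Homo sapiens) for cytotoxicity, read by sulforhodamine B assay, with a stated time of 72 h (a lower number here means a stronger inhibitor of growth, a higher number a weaker inhibitor of growth), compound 1 `C=C1CC[C@@H]2[C@](C)(CCC[C@]2(C)C(=O)OC)[C@H]1CCc1ccc2c(OC(C)=O)ccc(OC(C)=O)c2c1` gives 120 nM, a clear reading of growth inhibition. Compound 2 `C=C1CC[C@@H]2[C@](C)(CCC[C@]2(C)C(=O)OC)[C@H]1CCc1ccc2c(OC)ccc(OC)c2c1` gives > 6700 nM, which is a limit of the assay and not a number. That limit lies well above the reading for compound 1, so compound 2 stands on the high, weakly inhibiting side of the numbers shown, without an exact position. Compound 4 `C=C1[C@H](O)C[C@@H]2[C@](C)(CCC[C@]2(C)C(=O)OC)[C@H]1CCc1ccc2c(OC)ccc(OC)c2c1` is compound 2 with one change: hydroxy in place of hydrogen on a saturated ring carbon. This hydroxy group sits on a saturated ring carbon of the core. Compound 3 `C=C1[C@H](O)C[C@@H]2[C@](C)(CCC[C@]2(C)C(=O)OC)[C@H]1CCc1ccc2c(OC(C)=O)ccc(OC(C)=O)c2c1` also carries this hydroxy group, but its entry reads "not determined" (no result reported), so compound 3 offers no guide to what the group does. For the measured compounds named here, with no measured example of this change, no shift beyond the scatter is expected in this assay. The expected change, a step that the limit leaves unreadable from compound 2 to compound 4, is therefore small and uncertain. Compound 4 is estimated at 7000 nM, with an expected range from 2500 nM to 15000 nM.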

Compound 4, concentration for 50% growth inhibition: > 6400 nM
Compound 4 ended at the assay's limit; the forecaster's own chance of this, stated with the estimate: 70%; the middle value is on the limit's open side.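

For the compounds shown here, compound 2 and compound 4 both ended at limits of this assay, not at numbers, so no step between them can be read. The compounds shown leave open whether hydroxy in place of hydrogen on a saturated ring carbon changes growth inhibition at all.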